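Hydroxy in Place of (Phenylcarbamoyl)amino: Stability Expected to Hold

The compounds below may be only part of what the source reports. "The series", "measured", "known", "first", "only" and "open" are said of these compounds alone.

Three close relatives were tested in an ADME assay on microsomes from liver (Homo sapiens) for metabolic stability, read by LC-MS, with NADPH named in the record, with a stated time of 60 min, tested at 1 uM, in the absence of a further agent; a lower number here means that less of the compound is left, a higher number that more of the compound is left. Compound 1 `COc1ccc(-n2c(C)nc3c(N4CC[C@@H](NC(C)=O)C4)nc(C)nc32)cc1OC` gives > 95%, which is a limit of the assay rather than a number. Compound 2 `COc1cc(-c2c(C)nc3c(N4CC[C@@H](NC(C)=O)C4)cc(C)nn23)ccc1F` likewise gives > 95% in this assay, again a limit. Compound 3 `COc1ccc(-c2c(C)nc3c(N4CC[C@@H](NC(=O)Nc5ccccc5)C4)cc(C)nn23)cc1OC` also sits at a limit, with > 95% in this assay. Compound 3 therefore stands where all three values sit, (the limit of > 95% in this assay, at which 3 of the 3 values shown sit), and the numbers give no ranking among them. Compound 4 `COc1ccc(-c2c(C)nc3c(N4CC[C@@H](O)C4)cc(C)nn23)cc1OC` has not yet been measured. It differs from compound 3 by hydroxy in place of (phenylcarbamoyl)amino on a saturated ring carbon. Among the measured compounds shown here, no measured step of this kind exists, so the expectation rests on the three limit values alone. Compound 4 is expected to give 93%, between 80% and 99%, in this assay. The step of a number at least 2 percentage points lower from compound 3 to compound 4 (that floor lies within the scatter) is expected to stay within the scatter.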

Compound 4, percent of the compound remaining: > 95%
Compound 4 ended at the assay's limit (the forecaster's own chance of this, stated with the estimate: 65%); at least 2 percentage points between middle value and limit.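

In this assay, among the compounds shown here, compound 3 and compound 4 both sit at a limit, so no step between them can be read. The compounds shown leave open whether hydroxy in place of (phenylcarbamoyl)amino alters how much compound remains.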